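An unmeasured 1,3-benzothiazol-2-yl analogue of compound 2

This account rests on a few compounds, and the source may have more. Where it says the series, first, only, none or still open, it means among the compounds named here.

Measured so far in a functional assay on MCF7 cells (Homo sapiens) for antiproliferative activity, read by MTT assay, with a stated time of 48 h; on this read-out higher numbers stand for weaker inhibition and lower numbers for stronger inhibition:
compound 1 `Cc1ccc(-c2nn(-c3ccccc3)cc2C(Nc2nc3cc(C)c(C)cc3s2)c2c(O)ccc3ccccc23)cc1`: 22400 nM
compound 2 `Cc1cc2nc(NC(c3cn(-c4ccccc4)nc3-c3ccc([N+](=O)[O-])cc3)c3c(O)ccc4ccccc34)sc2cc1C`: 41100 nM
compound 3 `Oc1ccc2ccccc2c1C(Nc1nc2ccccc2s1)c1cn(-c2ccccc2)nc1-c1ccccc1`: 48900 nM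

Compound 2 holds the second highest of these three numbers, and it lies within the scatter of both compound 1 and compound 3. Compound 4 `O=[N+]([O-])c1ccc(-c2nn(-c3ccccc3)cc2C(Nc2nc3ccccc3s2)c2c(O)ccc3ccccc23)cc1` has not yet been measured. It departs from compound 2 in one place, on an amine nitrogen: 1,3-benzothiazol-2-yl in place of 5,6-dimethyl-1,3-benzothiazol-2-yl on an amine nitrogen.

Among the measured compounds shown here, no measured step isolates this change. For the measured compounds named here, the only step available, a 1.8-fold higher number from compound 1 to compound 2 (0.26 log units; within the scatter), concerns a different change, nitro in place of methyl on an aromatic carbon, and it stays within the scatter. Compound 3 also carries 1,3-benzothiazol-2-yl, but it differs from compound 1 in more than one place, so their two values cannot be assigned to this change alone. No step beyond the scatter is therefore expected in this assay, in either direction. The expected change is a 1.2-fold higher number from compound 2 to compound 4 (0.07 log units; within the scatter). Compound 4 is estimated at 48000 nM, with an expected range of 22000 nM to 100000 nM.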

Compound 4, half-maximal inhibitory concentration: 14700 nM
For compound 4 the middle estimate is 3.3-fold (0.51 log units) above the measured one, and the stated range ends above it.
By their numbers in this assay, from the lowest: compounds 4, 1, 2 and 3 (each within the scatter of the next, the first and the last beyond it).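

In this assay the first step read at this position, 1,3-benzothiazol-2-yl in place of 5,6-dimethyl-1,3-benzothiazol-2-yl on the amine nitrogen, gives a 2.8-fold lower number from compound 2 to compound 4 (0.45 log units; beyond the scatter) and so shows that this position can move the number beyond the scatter, though only modestly. With 1,3-benzothiazol-2-yl on that nitrogen, introducing the nitro group gives a 3.3-fold lower number from compound 3 to compound 4 (0.52 log units; beyond the scatter) and is likewise modest but beyond the scatter. Nothing available accounts for either step.

As far as these compounds go, whether one methyl on the 1,3-benzothiazol-2-yl group would give a number nearer compound 2 or compound 4 remains open, as does the effect of a methoxy group or chlorine there. From the compounds shown here alone, it is also open how an amine would compare with nitro on the same aromatic carbon.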